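Adding a methyl to compound 1: clearance outlook

The source may hold more compounds than are shown below. What is called first, only, known or untested is meant among the compounds shown, and "the series" means these compounds.

In an ADME assay on microsomes from liver (Rattus norvegicus) for pharmacokinetics (a higher number here means faster removal of the compound, a lower number slower removal), compound 1 `O=C(NCc1cc(-c2ccc(C(F)(F)F)nc2)ncn1)[C@@H]1CCCN1S(=O)(=O)c1ccc(F)cc1` gives 43 mL/min/kg and compound 2 `O=C(NCc1cc(-c2ccc(C(F)(F)F)nc2)ncn1)[C@@H]1CCCCN1S(=O)(=O)c1ccc(F)cc1` gives 46 mL/min/kg in the same test, so the two stand within the scatter of each other and neither is clearly set apart. Compound 3 `C[C@@H]1CC[C@@H](C(=O)NCc2cc(-c3ccc(C(F)(F)F)nc3)ncn2)N1S(=O)(=O)c1ccc(F)cc1` carries one change from compound 1: methyl in place of hydrogen on a saturated ring carbon (methyl in place of hydrogen on a saturated ring carbon, next to the ring nitrogen). Among the measured compounds shown here, no measured pair here shows the effect of this change, so the expectation rests on the value of compound 1 at 43 mL/min/kg as its starting point. The expected step of a 1.1-fold higher number from compound 1 to compound 3 (0.05 log units; within the scatter) is small, slightly upward and within the scatter of this assay as a working estimate. For compound 3 the estimate is 48 mL/min/kg with an expected range from 30 mL/min/kg to 75 mL/min/kg for a single measurement.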

Compound 3, clearance in the liver assay: 30 mL/min/kg
Beside the measured number, compound 3's estimate is 1.6-fold (0.20 log units) above it; the measured number falls inside the stated range.
By their numbers in the liver assay, from the lowest: compounds 3, 1 and 2 (each within the scatter of the next).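

Among the compounds shown here, in the liver assay the methyl on a saturated ring carbon, next to the ring nitrogen, gives a 1.4-fold lower number from compound 1 to compound 3 (0.16 log units; within the scatter), so this position takes the added carbon with no step in clearance beyond the scatter. Compounds 1 and 2 carry only hydrogen at this position, so they could not show this. In a physicochemical assay for lipophilicity, at pH 7.4 (a lower number here means a more polar compound, a higher number a more lipophilic compound), compound 1 gives 2.7 and compound 3 gives 4.3, so the same change makes compound 3 far more lipophilic, and no clearance step beyond the scatter comes with it: the measured distribution coefficient of compound 1, 2.7, and of compound 3, 4.3, a number 1.60 log units higher (beyond the scatter)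

This single pair leaves open whether the methyl would act the same way on compound 2. It also leaves open whether an ethyl, a hydroxymethyl or an amine at this position would keep clearance within the scatter of compound 1 while the distribution coefficient stays nearer that of compound 1.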